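The source may report more compounds than this note shows. Statements on the series, on what has been measured and on what is new or still open speak of the compounds shown alone.

Measured in a functional assay on CWR22R cells (Homo sapiens) for antiproliferative activity, read by CCK-8 assay, with a stated time of 6 days; on this read-out lower numbers stand for stronger inhibition and higher numbers for weaker inhibition:
Compound 1 `CCN(c1ccc(C#N)c(Cl)c1)c1cc(-n2cnc3ccccc32)ccc1C`: 3040 nM
Compound 2 `CCN(c1ccc(C#N)c(Cl)c1)c1cc(-c2ccnn2C)ccc1C`: 4330 nM
Compound 3 `CCN(c1ccc(C#N)c(Cl)c1)c1cc(-c2c[nH]nc2C)ccc1C`: 5380 nM

These three compounds share one core and differ only in the ring group on an aromatic carbon. Compound 3 lies within the usual scatter of both others, with a 1.2-fold higher number from compound 2 to compound 3 (0.09 log units; within the scatter) and a 1.8-fold higher number from compound 1 to compound 3 (0.25 log units; within the scatter). The measurements therefore do not separate it from either one.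

Compound 4 `CCN(c1ccc(C#N)c(Cl)c1)c1cc(-c2ccoc2)ccc1C` carries furan-3-yl in place of 3-methyl-1H-pyrazol-4-yl on an aromatic carbon. Going by the values given here, none of the measured compounds contains furan-3-yl, so the data offer only an indirect guide. The closest guides are the other exchanges of ring groups at this position. Besides the two steps above, there is a 1.4-fold higher number from compound 1 to compound 2 (0.15 log units; within the scatter). All three stay within the scatter, even the exchange involving the larger 1H-benzimidazol-1-yl group. On that evidence, no step beyond the scatter is expected in this assay, in either direction. Three compounds are a thin basis, however, so the range is kept wide.

The expected step is a 1.3-fold lower number from compound 3 to compound 4 (0.11 log units; within the scatter). For compound 4 the estimated value is 4200 nM, with an expected range from 1900 nM to 9500 nM.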

Compound 4, half-maximal inhibitory concentration: > 30000 nM
Compound 4 gave a limit, no number (the forecaster's own chance of this, stated with the estimate: 3%); at least 7.1-fold (0.85 log units) between middle value and limit.
By their numbers in this assay, from the lowest: compounds 1, 2 and 3 (each within the scatter of the next). At a limit, above all of these: compound 4.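

In this assay, compound 4 gave only a limit of the assay and no number: the limit of > 30000 nM in this assay, at which 1 of the 4 values shown sits. Even so, the exchange of ring groups on this aromatic carbon now produces steps beyond the scatter, with an at least 5.5-fold higher number from compound 3 to compound 4 (0.74 log units; beyond the scatter), an at least 6.9-fold higher number from compound 2 to compound 4 (0.84 log units; beyond the scatter) and an at least 9.8-fold higher number from compound 1 to compound 4 (0.99 log units; beyond the scatter). The position is therefore not indifferent to its ring group, as the earlier exchanges alone might have suggested, and among these four compounds the three rings that give a number all contain nitrogen, while furan-3-yl holds oxygen and no nitrogen.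

The compounds shown cannot say whether the missing nitrogen is what matters, whether the lost hydrogen-bond donor of compound 3 plays a part, or how high the true number of compound 4 lies. A thiophen-3-yl or phenyl group on the same carbon, or an amine in place of the ring, would be needed to show whether any ring without nitrogen behaves like furan-3-yl.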